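Compound 2 to compound 3: phenoxymethyl leaves the chain

The source may hold more compounds than are shown below. What is called first, only, known or untested is meant among the compounds shown, and "the series" means these compounds.

Measured in an ADME assay (liver) for pharmacokinetics, with Liver microsome (Homo sapiens) as the target, using microsomes; on this read-out lower numbers stand for a shorter-lived compound and higher numbers for a longer-lived compound:
- Compound 1 `CCCCCCOC(=O)/C=C/c1ccc(NC(=O)C2(NC(=O)c3ccc4c(C5CCCC5)c(-c5ncc(Cl)cn5)n(C)c4c3)CCC2)cc1OCC`: 17.9 h
- Compound 2 `CCOc1cc(NC(=O)C2(NC(=O)c3ccc4c(C5CCCC5)c(-c5ncc(Cl)cn5)n(C)c4c3)CCC2)ccc1/C=C/C(=O)OCCOc1ccccc1`: > 5 h (a limit)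

Compound 2 stands only at a limit, > 5 h, and this is the limit of > 5 h in this assay, at which 1 of the 2 values shown sits. Compound 3 `CCOc1cc(NC(=O)C2(NC(=O)c3ccc4c(C5CCCC5)c(-c5ncc(Cl)cn5)n(C)c4c3)CCC2)ccc1/C=C/C(=O)OCC(=O)N(C)C(C)C` carries isopropyl(methyl)carbamoyl in place of phenoxymethyl on a saturated chain carbon bound to an oxygen next to a carbonyl group. Among the compounds with values here, the one measured change on this chain is a step that the limit leaves unreadable from compound 1 to compound 2, so it offers no size to carry over. The estimated change is a step that the limit leaves unreadable from compound 2 to compound 3, with no direction expected beyond the scatter. For compound 3 the estimate is 8 h, with an expected range of 2.5 h to 25 h.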

Compound 3, half-life: 0.65 h
For compound 3 the middle estimate is 12-fold (1.09 log units) above the measured one, outside the stated range (below it).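

In this assay, this place now gives a readable change: isopropyl(methyl)carbamoyl in place of phenoxymethyl gives an at least 7.6-fold lower number from compound 2 to compound 3 (0.88 log units; beyond the scatter), and the same group in place of pentyl gives a 28-fold lower number from compound 1 to compound 3 (1.44 log units; beyond the scatter). The group on this saturated chain carbon therefore matters to the half-life, which the unreadable step between the first two compounds could not show. The value of compound 2 is a limit, so the full size of its step stays open: the limit of > 5 h in this assay, at which 1 of the 3 values shown sits.

The compounds shown leave open whether a shorter chain such as ethyl would stay nearer compound 1 or compound 3. They also leave open how a dimethylcarbamoyl group in place of isopropyl(methyl)carbamoyl would compare.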